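Dimethylamino in Place of Phenoxy: From Compound 2 to Compound 3

The source may hold more compounds than are shown below. What is called first, only, known or untested is meant among the compounds shown, and "the series" means these compounds.

Compound 1, `COc1cc(C)cc(-c2nn(CC#N)cc2-c2ccc(-c3cccc(C(C)=O)c3)nc2)c1`: 90%
Compound 2, `Cc1cc(O)cc(-c2nn(CC#N)cc2-c2ccnc(-c3ccc(Oc4ccccc4)cc3)c2)c1`: 84%

For the measured compounds named here, in a functional assay on UACC-62 cells (Homo sapiens) for cytotoxicity, read by sulforhodamine B assay, with a stated time of 48 h, tested at 0.01 uM (a lower number here means a stronger effect, a higher number a weaker effect of the compound at the concentration tested), compound 2 gives 84%, the lower of the two numbers so far. Compound 1 gives 90% in this assay, and the gap between the two lies within the usual scatter, so no order between them can be claimed. Compound 3, `Cc1cc(O)cc(-c2nn(CC#N)cc2-c2ccnc(-c3ccc(N(C)C)cc3)c2)c1`, has not yet been measured. It differs from compound 2 in one place: dimethylamino in place of phenoxy on an aromatic carbon. Going by the values given here, no step between two measured compounds is available for this change, so the effect of it in this assay cannot be read from anything measured here. Compound 3 is expected to give 85% in this assay, with a range from 70% to 100%. The estimated step of a number 1 percentage points higher from compound 2 to compound 3 (within the scatter) is expected to stay within the scatter, in no clear direction.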

Compound 3, a percentage reported as activity, at one concentration (the size of the read-out at that concentration, not a potency): 96%
The estimate for compound 3 lay 11 percentage points below the measured number; the measured number falls inside the stated range.
By their numbers in this assay, from the lowest: compounds 2, 1 and 3 (each within the scatter of the next, the first and the last beyond it).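

For the compounds shown here, this is the first change at a single place that can be read in this assay: on an aromatic carbon para to a large group, dimethylamino in place of phenoxy gives a number 12 percentage points higher from compound 2 to compound 3 (beyond the scatter), which means a weaker effect at the concentration tested. The change removes a six-membered aromatic ring and shrinks the substituent from 7 heavy atoms to 3, while the counts of hydrogen-bond donors and acceptors stay the same. Nothing measured here accounts for the step.

Going by these compounds, whether methoxy, a smaller ether, or morpholine, a ring-bearing amine, would read like phenoxy or like dimethylamino at this place remains open. So does whether the step would hold at other concentrations, since this read-out reflects a single concentration and not a potency.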